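This account rests on a few compounds, and the source may have more. Where it says the series, first, only, none or still open, it means among the compounds named here.

Of the compounds shown here, three have been measured in an ADME assay on SW480 cells (Homo sapiens) for cytotoxicity, read by MTT assay, with a stated time of 72 h; a higher number here means a weaker inhibitor, a lower number a stronger inhibitor.

Compound 1, `Cc1ccc(N2C(=O)C/C(=C\c3cccc(C(=O)Nc4cccc(F)c4)c3)C2=O)cc1`, gives 96900 nM.
Compound 2, `O=C(Nc1ccc(OC(F)F)cc1)c1cccc(/C=C2\CC(=O)N(c3ccccc3)C2=O)c1`, gives only a limit, > 100000 nM.
Compound 3, `CCCCCN1C(=O)C/C(=C\c2cccc(C(=O)NCCCC)c2)C1=O`, gives only a limit, > 100000 nM.

Compound 2 stands at the limit of > 100000 nM in this assay, at which 2 of the 3 values shown sit, so its value in this assay is a limit rather than a number. Going by the values given here, the one numerical value in the set, that of compound 1, lies close to that same limit. Among the compounds with values here, no pair of measured compounds differs in a single place, so no measured step is available to guide an expectation about the next compound.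

The unmeasured compound 4, `O=C(Nc1ccc(Cl)cc1)c1cccc(/C=C2\CC(=O)N(c3ccccc3)C2=O)c1`, differs from compound 2 by chloro in place of difluoromethoxy on an aromatic carbon. With two limits and one nearby number, nothing in the measured set points to a direction for this change. The estimate for compound 4 therefore implies a step of a number no higher from compound 2 to compound 4 (the limit leaves the size open), which is expected to be none beyond the usual scatter. On that basis compound 4 is estimated at 100000 nM, with a range from 40000 nM to 300000 nM, and it is considered likely that this assay reports only a limit for it as well.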

Compound 4, half-maximal inhibitory concentration: > 100000 nM
Compound 4: only a limit was reported; the forecaster's own chance of this, stated with the estimate: 60%; the middle value lies on the limit itself.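

In this assay compound 4 gives > 100000 nM, which is a limit and not a number. Compound 2 also stands only at a limit, so no step can be read between compound 2 and compound 4. The compounds shown leave open whether chloro or difluoromethoxy at this place gives the stronger inhibitor.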